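A few compounds are considered here, and "the series" means these few. Any claim that something is new, unique, unknown or untested is made for them only; others in the source may bear on it.

Compound 1 `COc1ccccc1NC1=CC(=O)c2nc3n(c2C1=O)[C@H]1OC[C@@H](O)[C@H]1OC3`: > 4000 nM (a limit)
Compound 2 `CCOc1ccccc1NC1=CC(=O)c2nc3n(c2C1=O)[C@H]1OC[C@@H](O)[C@H]1OC3`: 4630 nM

Among the compounds with values here, in a functional assay on ECa-109 cells for inhibition, with ECa-109 cell line (Homo sapiens) as the target, read by sulforhodamine B assay (on this read-out lower numbers stand for stronger inhibition and higher numbers for weaker inhibition), compound 2 gives 4630 nM, the only actual number so far. The entry for compound 1, > 4000 nM, is a limit of the assay and not a number (the limit of > 4000 nM in this assay, at which 1 of the 2 values shown sits).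

Compound 3 `Cc1ccc(NC2=CC(=O)c3nc4n(c3C2=O)[C@H]2OC[C@@H](O)[C@H]2OC4)cc1` is still to be measured in this assay. It differs from compound 2 in one place: 4-methylphenyl in place of 2-ethoxyphenyl on an amine nitrogen. Within the data shown here, the only measured step, a step that the limit leaves unreadable from compound 1 to compound 2, has no readable size, so it gives no guide to this change. The expectation therefore rests on compound 2 at 4630 nM alone. The expected change is a 1.2-fold lower number from compound 2 to compound 3 (0.06 log units; within the scatter), with no shift beyond the scatter foreseen in either direction. The estimate for compound 3 is 4000 nM, with an expected range of 1300 nM to 12000 nM.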

Compound 3, half-maximal inhibitory concentration: 3480 nM
For compound 3 the middle estimate is 1.1-fold (0.06 log units) above the measured one, within the range that was stated.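

In this assay, within the data shown here, replacing 2-ethoxyphenyl with 4-methylphenyl on the amine nitrogen gives a 1.3-fold lower number from compound 2 to compound 3 (0.12 log units; within the scatter), so this is the first readable change at this position, and it produces no shift beyond the scatter. The comparison with the methoxy compound gives only a floor, an at least 1.1-fold lower number from compound 1 to compound 3 (0.06 log units; that floor lies within the scatter), so it adds no evidence of a real difference. The entry for compound 1 remains a limit of the assay: the limit of > 4000 nM in this assay, at which 1 of the 3 values shown sits.

Still open, on these data alone, is whether a carboxylic acid or an amine on this phenyl ring would move the number beyond the scatter. Also open, as far as these compounds go, is what a plain phenyl ring, or a longer alkyl chain in place of the ring on the amine nitrogen, would give in this assay.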